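This account rests on a few compounds, and the source may have more. Where it says the series, first, only, none or still open, it means among the compounds named here.

Two cytotoxicity read-outs are in hand for this series. In an ADME assay on BJ cells (Homo sapiens) for cytotoxicity, with a stated time of 72 h (on this read-out higher numbers stand for an effect only at larger amounts of compound and lower numbers for an effect already at smaller amounts), compound 1 `CCc1ccc(-c2nc3c(c(C)nn3-c3ccccc3)c(-c3ccccc3C(=O)O)c2C#N)cc1` reaches only the limit > 20000 nM. Compound 2 `Cc1cccc(-c2nc3c(c(C)nn3-c3ccccc3)c(-c3ccccc3O)c2C#N)c1` likewise gives only the limit > 20000 nM in this assay. Compound 2 therefore stands at the limit of > 20000 nM in this assay, at which 2 of the 2 values shown sit, and no numbered gap between the two measured compounds can be read from these values. Compound 3 `CCc1cccc(-c2nc3c(c(C)nn3-c3ccccc3)c(-c3ccccc3O)c2C#N)c1` is the next member to be measured in this assay. It differs from compound 2 by methyl in place of hydrogen on a saturated chain carbon bound to an aromatic carbon. For the measured compounds named here, no step between measured compounds is known, so the size of this change in this assay is open; with both values so far at the assay limit, no movement beyond the usual scatter is expected, and the most probable outcome is that compound 3 again reaches only the limit. Compound 3 is estimated at 20000 nM, within 10000 nM to 40000 nM. The step that this estimate implies from compound 2 to compound 3 is a number no higher from compound 2 to compound 3 (the limit leaves the size open).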

Compound 3, half-maximal effective concentration: > 20000 nM
Compound 3: a limit, no number (the forecaster's own chance of this, stated with the estimate: 80%); the middle value sits exactly at the limit.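

In this assay, for the compounds shown here, compound 2 and compound 3 both give only a limit, so no step between them can be read from the methyl-to-ethyl change: the limit of > 20000 nM in this assay, at which 3 of the 3 values shown sit. The compounds shown leave open whether any change on the shared core yields a numerical value rather than a limit.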